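Swapping the Amide Substituent in a Cytotoxic Series

A few compounds are considered here, and "the series" means these few. Any claim that something is new, unique, unknown or untested is made for them only; others in the source may bear on it.

Measured in a functional assay on PC-3 cells (Homo sapiens) for cytotoxicity, read by XTT assay, with a stated time of 72 h; on this read-out higher numbers stand for weaker inhibition and lower numbers for stronger inhibition:
Compound 1 `CN(Cc1ccccc1)C(=O)c1ccc(-c2cc(C3=CC(=O)C=CC3=O)no2)s1` gives 11000 nM.
Compound 2 `COc1ccc(CN(C)C(=O)c2ccc(-c3cc(C4=CC(=O)C=CC4=O)no3)s2)cc1` gives < 30000 nM, which is a limit of this assay and not a number.
Compound 3 `COc1ccc(OC)c(-c2cc(-c3ccc(C(=O)N(C)Cc4ccccc4)s3)on2)c1` gives > 30000 nM, which is likewise a limit and not a number.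

For the measured compounds named here, compound 1 thus stands as the only compound of the three with a number in this assay; the other two values are limits. Compound 4 `O=C1C=CC(=O)C(c2cc(-c3ccc(C(=O)NCC4CC4)s3)on2)=C1` differs from compound 1 by (cyclopropylmethyl)amino in place of benzyl(methyl)amino on a carbonyl carbon. Neither measured step touches that position: the step that the limit leaves unreadable from compound 1 to compound 2 concerns a methoxy on an aromatic carbon, and the step of an at least 2.7-fold higher number from compound 1 to compound 3 (0.43 log units; beyond the scatter) concerns the ring bearing two oxygens. Going by the values given here, no measured step therefore bears on the change from compound 1 to compound 4, and the expectation is anchored on compound 1 alone, with no step beyond the scatter expected in either direction, so that the estimated step of no change at the digits printed from compound 1 to compound 4 (within the scatter) is close to none. Compound 4 is accordingly estimated at 11000 nM, between 3500 nM and 30000 nM.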

Compound 4, half-maximal inhibitory concentration: > 30000 nM
Compound 4 ended at the assay's limit (the forecaster's own chance of this, stated with the estimate: 25%); middle value at least 2.7-fold (0.43 log units) from the limit.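

For the compounds shown here, at the amide position, which no earlier step touched, the replacement on the carbonyl carbon gives an at least 2.7-fold higher number from compound 1 to compound 4 (0.43 log units; beyond the scatter) in this assay, so the shared core alone does not keep the activity of compound 1. Compound 4 gives > 30000 nM, which is a limit of the assay and not a number. The step therefore has a known direction but no upper bound on its size, because compound 4 sits at an assay limit: the limit of > 30000 nM in this assay, at which 2 of the 4 values shown sit.

The change removes the benzyl(methyl)amino group and brings in an amide hydrogen at once, so the compounds shown do not separate these two differences, and a benzylamino or dimethylamino group at this place would be needed to do so. The step from compound 1 to compound 2 cannot be read, which leaves open how the methoxy group acts on the benzyl ring.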